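Isoxazole-fused acid series: lactam in place of open amide

The source may hold more compounds than are shown below. What is called first, only, known or untested is meant among the compounds shown, and "the series" means these compounds.

Three compounds carry the shared core of compound 1 `O=C(O)c1ccc2noc(-c3ccc(-c4cccnc4)cc3)c2c1` with a varied group on the distal phenyl ring. In an assay for inhibition of inositol hexakisphosphate kinase 3 (Homo sapiens), read by colorimetric assay, coupled enzyme assay and malachite green, with a stated time of 120 min, in the presence of a further agent that is not named here (a higher number here means a weaker inhibitor, a lower number a stronger inhibitor), compound 1 gives 610 nM. Compound 2 `O=C(O)c1ccc2noc(-c3ccc(-c4ccncc4)cc3)c2c1` gives 670 nM, and the step of a 1.1-fold higher number from compound 1 to compound 2 (0.04 log units; within the scatter) is within the scatter. Compound 3 `CC(C)C(=O)Nc1ccc(-c2onc3ccc(C(=O)O)cc23)cc1` gives 210 nM, the lowest of the three numbers; the steps of a 2.9-fold lower number from compound 1 to compound 3 (0.46 log units; beyond the scatter) and a 3.2-fold lower number from compound 2 to compound 3 (0.50 log units; beyond the scatter) are both beyond the scatter, so compound 3 stands apart from compound 1 and compound 2 on this assay.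

Compound 4 `O=C(O)c1ccc2noc(-c3ccc(N4CCCC4=O)cc3)c2c1` differs from compound 3 by 2-oxopyrrolidin-1-yl in place of (isopropylcarbonyl)amino on an aromatic carbon. For the measured compounds named here, no measured pair shows an exchange of the (isopropylcarbonyl)amino group for a 2-oxopyrrolidin-1-yl group, so the two steps that end at compound 3 are the only guide: they show that the (isopropylcarbonyl)amino group yields a lower number than either pyridyl group, at a modest size. The change to compound 4 keeps the count of heavy atoms and the one hydrogen-bond acceptor and removes the one hydrogen-bond donor. The expected step of a 1.7-fold higher number from compound 3 to compound 4 (0.22 log units; within the scatter) is small, at most modest, and more likely toward a higher number than a lower one. For compound 4 the estimate in this assay is 350 nM, with a range from 150 nM to 900 nM.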

Compound 4, half-maximal inhibitory concentration: 2170 nM
Estimate against measurement, compound 4: 6.2-fold (0.79 log units) below; measured number outside the range, above it.
By their numbers in this assay, from the lowest: compound 3; then compounds 1 and 2 (each within the scatter of the next); then compound 4.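

Working notes: with the heavy-atom make-up unchanged, the exchange of (isopropylcarbonyl)amino for 2-oxopyrrolidin-1-yl on this aromatic carbon, para to a large group, is not a neutral one in this assay, giving a 10-fold higher number from compound 3 to compound 4 (1.01 log units; beyond the scatter); the listed differences are the added five-membered non-aromatic ring and the lost amide hydrogen. The low number of compound 3 therefore does not carry over to every group of this atom make-up, since 2-oxopyrrolidin-1-yl also gives a higher number than either pyridyl group, with a 3.2-fold higher number from compound 2 to compound 4 (0.51 log units; beyond the scatter) and a 3.6-fold higher number from compound 1 to compound 4 (0.55 log units; beyond the scatter). Nothing available explains the size of these steps.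

Because the ring and the amide hydrogen change together in the one step, the compounds shown do not separate their contributions. An open N-methyl amide would lack the amide hydrogen without the ring, and a cyclopropylcarbonylamino group or a longer acyl chain on the retained amide hydrogen would show how far the acyl part can vary at this position.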